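Replacing the Furanyl Amide with a Cinnamoyl Group

The source may hold more compounds than are shown below. What is called first, only, known or untested is meant among the compounds shown, and "the series" means these compounds.

Compound 3 `CCCCCCCCCCCCCCNC(=O)[C@@H](NC(=O)c1ccco1)[C@@H](C)O` gives 105000 nM in a functional assay on MCF7 cells (Homo sapiens) for cytotoxicity, read by MTT assay, with a stated time of 48 h (a lower number here means a stronger inhibitor, a higher number a weaker inhibitor), the highest number among the three measured compounds. Compound 1 `CCCCCCCCNC(=O)[C@@H](NC(=O)c1ccco1)[C@@H](C)O` gives 91800 nM, and compound 2 `CCCCCCCCCCCCCCNC(=O)[C@@H](NC(=O)c1ccccc1)[C@@H](C)O` gives 24800 nM. The step of a 1.1-fold higher number from compound 1 to compound 3 (0.06 log units; within the scatter) lies within the scatter, whereas a 4.2-fold higher number from compound 2 to compound 3 (0.63 log units; beyond the scatter) is a modest loss. Compound 4 `CCCCCCCCCCCCCCNC(=O)[C@@H](NC(=O)/C=C/c1ccccc1)[C@@H](C)O` differs from compound 3 by 2-phenylethenyl in place of furan-2-yl on a carbonyl carbon. Among the measured compounds shown here, no measured step covers this exact exchange; the closest guide is compound 2, whose 24800 nM sits below that of compound 3, and the 2-phenylethenyl group carries the same six-membered aromatic ring of carbon only. A decrease is therefore expected, roughly reversing the modest step of a 4.2-fold higher number from compound 2 to compound 3 (0.63 log units; beyond the scatter), though with wide uncertainty. Compound 4 is estimated at 35000 nM, between 12000 nM and 100000 nM, an expected step of a 3.0-fold lower number from compound 3 to compound 4 (0.48 log units; beyond the scatter).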

Compound 4, half-maximal inhibitory concentration: 64600 nM
For compound 4 the middle estimate is 1.8-fold (0.27 log units) below the measured one, and the stated range covers the measured number.
By their numbers in this assay, from the lowest: compound 2; then compounds 4, 1 and 3 (each within the scatter of the next).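

In this assay, 2-phenylethenyl in place of furan-2-yl on the carbonyl carbon makes no difference beyond the scatter (a 1.6-fold lower number from compound 3 to compound 4 (0.21 log units; within the scatter)), so this exchange does not repeat the gain seen with phenyl. Setting 2-phenylethenyl in place of phenyl at the same carbonyl carbon gives a modest loss (a 2.6-fold higher number from compound 2 to compound 4 (0.42 log units; beyond the scatter)), so among these groups phenyl alone stands apart. No evidence is available to explain either step. On these data alone, it remains open how an amine or a carboxylic acid on the ring of the 2-phenylethenyl group would read, and whether a saturated 2-phenylethyl group would match 2-phenylethenyl.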